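Replacing dimethylcarbamoyl with 1H-pyrrol-2-yl when only limits are known

The compounds below may be only part of what the source reports. "The series", "measured", "known", "first", "only" and "open" are said of these compounds alone.

In a toxicity assay on NIH3T3 cells (Mus musculus) for cytotoxicity, read by resazurin assay (on this read-out lower numbers stand for an effect already at smaller amounts and higher numbers for an effect only at larger amounts of compound), compound 2 (`CN(C)C(=O)c1ccc(NCc2cncn2Cc2ccc(-c3ccccc3)cc2)cc1-c1ccccc1`) gives > 1000 nM, which is a limit and not a number. Compound 1 (`CCC(=O)c1ccc(NCc2cncn2Cc2ccc(-c3ccccc3)cc2)cc1-c1ccccc1`) gives > 10000 nM, again only a limit. Within the data shown here, the one measured step, a step that the two limits leave unreadable from compound 1 to compound 2, therefore offers no size to carry forward. Compound 3 (`c1ccc(-c2ccc(Cn3cncc3CNc3ccc(-c4ccc[nH]4)c(-c4ccccc4)c3)cc2)cc1`) carries 1H-pyrrol-2-yl in place of dimethylcarbamoyl on an aromatic carbon. No firm direction can be expected in this assay, and another limit may well appear. The expected step is a step that the limit leaves unreadable from compound 2 to compound 3, a rough estimate. For compound 3 the estimated value is 3000 nM, with an expected range of 800 nM to 15000 nM.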

Compound 3, half-maximal effective concentration: > 10000 nM
Compound 3: a limit, no number; the forecaster's own chance of this, stated with the estimate: 65%; middle value at least 3.3-fold (0.52 log units) away from the limit.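

Among these compounds, compound 1, compound 2 and compound 3 all give limits rather than numbers, so no step between them can be read. Going by these compounds, how much of each compound produces a half-maximal toxic effect on these cells remains open.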